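The source may hold more compounds than are shown below. What is called first, only, known or untested is meant among the compounds shown, and "the series" means these compounds.

Measured so far:
Compound 1 `N/C(=N\NC(=S)N1CCCCCC1)c1ccccn1`: 67%
Compound 2 `N/C(=N\NC(=S)N1CCSCC1)c1ccccn1`: 34%
Compound 3 `N/C(=N\NC(=S)N1CCSCC1)c1ccc(F)cn1`: 55.1%

In a functional assay on A-375 cells (Homo sapiens) for cytotoxicity, read by MTT assay, with a stated time of 72 h, tested at 1 uM (a lower number here means less inhibition of growth, a higher number more inhibition of growth at the concentration tested), compound 1 gives 67%, compound 2 gives 34% and compound 3 gives 55.1%. Compound 1 has the highest number of the three. The difference between the cores of compound 1 and compound 2 is not broken down here. Compound 3 arises from compound 2 by one change, (fluoro in place of hydrogen on an aromatic carbon), and that step is a number 21.1 percentage points higher from compound 2 to compound 3 (beyond the scatter). The unmeasured compound 4 `N/C(=N\NC(=S)N1CCCCCC1)c1ccc(F)cn1` arises from compound 1 by the same change, (fluoro in place of hydrogen on an aromatic carbon). Compound 4 is expected to give 78%, between 62% and 92%. The expected step is a number 11 percentage points higher from compound 1 to compound 4 (beyond the scatter), somewhat smaller than the earlier one because compound 1 already stands at 67% and the read-out cannot rise past complete inhibition of growth.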

Compound 4, percent growth inhibition at one concentration: 51.8%
Estimate against measurement, compound 4: 26.2 percentage points above; the measured number lies below the stated range.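

In this assay, putting fluoro in place of hydrogen on an aromatic carbon of the core of compound 1 gives a step of a number 15.2 percentage points lower from compound 1 to compound 4 (beyond the scatter). The same change therefore does not carry over between these two cores, and even its direction differs: the same change on two cores in this assay, a number 21.1 percentage points higher (beyond the scatter) from compound 2 to compound 3 and a number 15.2 percentage points lower (beyond the scatter) from compound 1 to compound 4, 36.3 percentage points apart, beyond the scatter of two such steps. This shows that, for these two pairs, a step measured on one core cannot be used to predict the step on the other, but it does not show why they differ or what the change would do on any further core.

The compounds shown leave open whether a chloro or a methoxy group in the same place would also split between the two cores. They also leave open which way fluoro would go on a third core.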